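From carboxy to cyclopropylcarbamoyl on the shared core

The source may hold more compounds than are shown below. What is called first, only, known or untested is meant among the compounds shown, and "the series" means these compounds.

Measured so far:
- Compound 1 `Cn1ncc(Cl)c1-c1cc(C(=O)N[C@@H]2CN[C@H](CC(O)CO)C[C@H]2c2ccc(Cl)c(Cl)c2)oc1Cl` gives 1110 nM
- Compound 2 `Cn1ncc(Cl)c1-c1cc(C(=O)N[C@@H]2CN[C@H](CCn3cncn3)C[C@H]2c2ccc(Cl)c(Cl)c2)oc1Cl` gives 560 nM
- Compound 3 `Cn1ncc(Cl)c1-c1cc(C(=O)N[C@@H]2CN[C@H](CC(=O)O)C[C@H]2c2ccc(Cl)c(Cl)c2)oc1Cl` gives 4020 nM

In a functional assay on HCT-116 cells (Homo sapiens) for antiproliferative activity, read by sulforhodamine B assay, with a stated time of 72 h (on this read-out higher numbers stand for weaker inhibition and lower numbers for stronger inhibition), compound 3 stands highest of the three at 4020 nM and is the weakest inhibitor so far. Compound 4 `Cn1ncc(Cl)c1-c1cc(C(=O)N[C@@H]2CN[C@H](CC(=O)NC3CC3)C[C@H]2c2ccc(Cl)c(Cl)c2)oc1Cl` differs from it in one place, where carboxy becomes cyclopropylcarbamoyl (cyclopropylamino in place of hydroxy on a carbonyl carbon) with cyclopropylamino in place of hydroxy on a carbonyl carbon.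

Going by the values given here, no measured step makes this exact change, and no amide has been measured. The nearest evidence is the pair of steps that bring in the carboxy, a 3.6-fold higher number from compound 1 to compound 3 (0.56 log units; beyond the scatter) and a 7.2-fold higher number from compound 2 to compound 3 (0.86 log units; beyond the scatter) on the same chain. Both are modest. The two side chains without carboxy are separated only by a 2.0-fold lower number from compound 1 to compound 2 (0.30 log units; within the scatter) and so sit close together. Compound 4 also lacks the carboxy, so if it follows compound 1 at 1110 nM and compound 2 at 560 nM, a modest fall in the number is expected, though this transfer to a new group is uncertain.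

The step expected in this assay is a 4.5-fold lower number from compound 3 to compound 4 (0.65 log units; beyond the scatter) by this reasoning. For compound 4 the expected value is 900 nM with a range from 350 nM to 2500 nM as estimated here.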

Compound 4, half-maximal inhibitory concentration: 740 nM
Compound 4: middle estimate off by 1.2-fold (0.09 log units), on the high side; the range from low to high includes it.
By their numbers in this assay, from the lowest: compounds 2, 4 and 1 (each within the scatter of the next); then compound 3.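

In this assay, the change on this carbonyl carbon shows that replacing hydroxy alone is enough to move compound 3 out of its isolated position at the top of the series, a 5.4-fold lower number from compound 3 to compound 4 (0.73 log units; beyond the scatter), although the carbonyl stays on the same chain. Going by these compounds alone, the higher number of compound 3 therefore does not go with the carbonyl as such, since the cyclopropylcarbamoyl of compound 4 cannot be told apart from the two side chains without a carbonyl, a 1.3-fold higher number from compound 2 to compound 4 (0.12 log units; within the scatter) and a 1.5-fold lower number from compound 1 to compound 4 (0.18 log units; within the scatter), leaving the carboxy as the only group of the four that stands apart here. Nothing in the data gives a reason for this step or says what it rests on.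

From the compounds shown here alone, how methylamino or dimethylamino on this carbonyl carbon would compare with cyclopropylamino remains open, so the part played by the three-membered ring is unsettled. Also open, going by these compounds, is whether a methyl ester of the carboxy, or a longer chain carrying the same cyclopropylcarbamoyl, would read like compound 4 or like compound 3.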